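A few compounds are considered here, and "the series" means these few. Any claim that something is new, unique, unknown or untested is made for them only; others in the source may bear on it.

Measured so far:
compound 1 `CC1=C(C(=O)OCc2ccccc2)C(c2cccs2)NC(=S)N1`: 45%
compound 2 `CC1=C(C(=O)OCc2ccccc2)C(c2ccsc2)NC(=S)N1`: 10%
compound 3 `COC(=O)C1=C(C)N(C)C(=O)NC1c1cccs1`: 17%

In an assay on membranes from HEK293 cells for displacement of a labelled ligand from adenosine receptor A2b (Homo sapiens), read by scintillation counting, with a stated time of 30 min, tested at 1 uM (on this read-out higher numbers stand for more inhibition at the one concentration tested (going by the name of the read-out) and lower numbers for less inhibition), compound 1 gives 45%, compound 2 gives 10% and compound 3 gives 17%. The change thiophen-3-yl in place of thiophen-2-yl on a saturated ring carbon produced a step of a number 35 percentage points lower from compound 1 to compound 2 (beyond the scatter). Compound 4 `COC(=O)C1=C(C)N(C)C(=O)NC1c1ccsc1` carries the same kind of change on the core of compound 3, (thiophen-3-yl in place of thiophen-2-yl on a saturated ring carbon); here the saturated ring carbon is next to the ring atom that bears a methoxycarbonyl group and three ring bonds from the ring atom that bears a methyl group, whereas on the core of compound 1 it is next to the ring atom that bears a large group. The difference between the two cores is not broken down here. Resting on a number 35 percentage points lower from compound 1 to compound 2 (beyond the scatter) and on compound 3 already standing at 17%, the expected step is a number 12 percentage points lower from compound 3 to compound 4 (beyond the scatter), smaller than the earlier one since the read-out cannot fall far. Compound 4 is therefore expected to give 5% in this assay, between -5% and 20%.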

Compound 4, a percentage reported as inhibition, at one concentration (the size of the read-out at that concentration, not a potency): 26%
Beside the measured number, compound 4's estimate is 21 percentage points below it, and the stated range ends below it.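

In this assay, thiophen-3-yl in place of thiophen-2-yl on a saturated ring carbon gives a number 9 percentage points higher from compound 3 to compound 4 (within the scatter), so no effect of this change can be read on the core of compound 3. The change does not carry over from the core of compound 1 to the core of compound 3: the same change on two cores in this assay, a number 35 percentage points lower (beyond the scatter) from compound 1 to compound 2 and a number 9 percentage points higher (within the scatter) from compound 3 to compound 4, 44 percentage points apart, beyond the scatter of two such steps The two cores differ in more than one place, so these two pairs do not show which difference separates the steps, and they say nothing about any other core.

Open, from the compounds shown here alone, is how the change behaves on a core that differs from the core of compound 1 in one place only, such as a benzyl ester swapped for methoxycarbonyl. Also open, going by these compounds, is whether an amine or a carboxylic acid on the thiophene keeps any displacement.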